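This account rests on a few compounds, and the source may have more. Where it says the series, first, only, none or still open, it means among the compounds named here.

Measured compounds, in a functional assay on SMMC-7721 cells (Homo sapiens) for cytotoxicity, read by MTT assay, with a stated time of 72 h; a higher number here means a weaker inhibitor, a lower number a stronger inhibitor:

Compound 1, `CCCCc1ccc(NC(=O)CSC(=S)N[C@H]2CCOC2=O)cc1`, gives 27300 nM.
Compound 2, `O=C(CCl)Nc1ccc(C(=O)/C=C/c2ccccc2)cc1`, gives 12600 nM.
Compound 3, `O=C(CSC(=S)N[C@H]1CCOC1=O)Nc1ccc(C(=O)/C=C/c2ccc(Cl)cc2)cc1`, reaches only the limit of > 128000 nM.

Compound 1 and compound 2 each give a number in this assay, and the two numbers differ by more than the usual scatter, with compound 2 showing the lower value. Compound 3 does not give a number at all; what stands for it is a limit of the assay, as noted in the limit of > 128000 nM in this assay, at which 1 of the 3 values shown sits. Where compound 3 stands among the three can therefore only be put as: weaker than any number shown here, or beyond what the assay could resolve.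

Compound 4, `O=C(CSC(=S)N[C@H]1CCOC1=O)Nc1ccc(C(=O)/C=C/c2ccccc2)cc1`, is not yet measured. It differs from compound 3 in one place: hydrogen in place of chloro on an aromatic carbon. Among the measured compounds shown here, no measured pair here tracks exactly this change, so the size of the step is open. Compound 2, which carries the same unsubstituted phenyl ring on the same side, gives a number, 12600 nM, and this gives some ground to expect compound 4 to land at a number rather than a limit. Compound 4 is expected at about 60000 nM, somewhere between 15000 nM and 128000 nM, which would make the step of an at least 2.1-fold lower number from compound 3 to compound 4 (0.32 log units; beyond the scatter) an expected move toward a stronger inhibitor.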

Compound 4, half-maximal inhibitory concentration: > 128000 nM
Compound 4 gave a limit, no number (the forecaster's own chance of this, stated with the estimate: 40%); middle value at least 2.1-fold (0.32 log units) away from the limit.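

In this assay compound 4 also gives only a limit, > 128000 nM, and not a number; as both it and compound 3 stop at a limit, the step between them cannot be read, and going from 4-chlorophenyl to phenyl does not by itself bring a number into view: the limit of > 128000 nM in this assay, at which 2 of the 4 values shown sit. With the phenyl end held the same, putting the larger group with its five-membered non-aromatic ring in place of the chlorine on the saturated chain carbon gives an at least 10-fold higher number from compound 2 to compound 4 (1.00 log units; beyond the scatter), a clear move toward a weaker inhibitor, so the phenyl end alone does not secure the measurable value seen for compound 2. Putting (2-phenylethenyl)carbonyl in place of butyl on the aromatic carbon gives an at least 4.6-fold higher number from compound 1 to compound 4 (0.67 log units; beyond the scatter), which also moves toward a weaker inhibitor.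

Among the compounds shown here, how far chloro or hydrogen at this ring position shifts the value remains open, since no pair here compares them with a number on both sides. Going by these compounds, it is also open whether a methoxy group or an amine at this position, or a longer chain in place of butyl, would bring the value back within the range of the assay.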